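Turning the Amide Link Around

A few compounds are considered here, and "the series" means these few. Any claim that something is new, unique, unknown or untested is made for them only; others in the source may bear on it.

Compound 1 `COc1ccccc1NC(=O)c1cccc(-c2cc(=O)c3c(OC)c(OC)c(OC)cc3o2)c1`: 1990 nM
Compound 2 `COc1ccc(C(=O)Nc2cccc(-c3cc(=O)c4c(O)c(OC)c(OC)cc4o3)c2)cc1`: "not determined" (no result reported)

In a functional assay on RAW264.7 cells (Mus musculus) for inhibition, with stated times of 1 h and 24 h (on this read-out higher numbers stand for weaker inhibition and lower numbers for stronger inhibition), compound 2 is recorded as "not determined" (no result reported), so it has no place on the scale of numbers. Compound 3 `COc1ccccc1NC(=O)c1cccc(-c2cc(=O)c3c(O)c(OC)c(OC)cc3o2)c1` has the same atoms as compound 2, joined differently. The change is (2-methoxyphenyl)carbamoyl in place of ((4-methoxyphenyl)carbonyl)amino on an aromatic carbon. With no number for compound 2, the size of this step in this assay cannot be worked out, and no step beyond the usual scatter is expected in either direction. Going by the values given here, the only guide is compound 1, which carries the same (2-methoxyphenyl)carbamoyl group on a different core and gives 1990 nM. The expected value for compound 3 is therefore estimated at 1500 nM, with a likely range of 400 nM to 5500 nM.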

Compound 3, half-maximal inhibitory concentration: 2380 nM
Compound 3: the middle estimate sits 1.6-fold (0.20 log units) below what was measured; measured number inside the range.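

In this assay, hydrogen in place of methyl on an oxygen of the core gives a 1.2-fold higher number from compound 1 to compound 3 (0.08 log units; within the scatter), a step within the usual scatter. With the (2-methoxyphenyl)carbamoyl group in place, this assay therefore cannot tell a free hydroxyl on that oxygen from a methoxy group, something that compound 1 alone could not show. No measurement is available that would explain this result.

Going by these compounds, the step between compound 2 and compound 3 cannot be read, so the effect of turning the amide around stays unknown in this assay. On these data alone, it also remains open whether a longer chain on that oxygen, such as ethyl or propyl, or an amine on the same spot, would move the number beyond the scatter.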